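From Acetyl to Methylsulfonyl on the Ring Amine

The source may report more compounds than this note shows. Statements on the series, on what has been measured and on what is new or still open speak of the compounds shown alone.

Two measured compounds share one core. For the measured compounds named here, compound 1 `CCCCNc1nc(N)nc2c1CN(Cc1ccccc1)CC2` gives 0.06 uM in an assay on HEK293 cells for agonist activity at Toll-like receptor 8 (Homo sapiens), read by a luciferase reporter, with a stated time of 6 h (a higher number here means that more compound is needed for the effect, a lower number that less compound is needed), while compound 2 `CCCCNc1nc(N)nc2c1CN(C(C)=O)CC2` gives 0.5 uM, the highest of the two numbers; the single measured step, an 8.3-fold higher number from compound 1 to compound 2 (0.92 log units; beyond the scatter), lies between them. Compound 3 `CCCCNc1nc(N)nc2c1CN(S(C)(=O)=O)CC2` carries methylsulfonyl in place of acetyl on an amine nitrogen in a ring. Going by the values given here, no measured step bears directly on this change, so the expectation rests on compound 2 alone, and a step no larger than the scatter, or a small rise, is expected. Compound 3 is therefore estimated at 0.8 uM, between 0.2 uM and 3 uM, which would be a step of a 1.6-fold higher number from compound 2 to compound 3 (0.20 log units; within the scatter).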

Compound 3, minimum effective concentration: 9.9 uM
Compound 3: middle estimate off by 12-fold (1.09 log units), on the low side, and the stated range ends below it.
By their numbers in this assay, from the lowest: compound 1; then compound 2; then compound 3.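

In this assay, the step from acetyl to methylsulfonyl on this amine nitrogen in a ring is large, a 20-fold higher number from compound 2 to compound 3 (1.30 log units; beyond the scatter), so the two groups are far from interchangeable here. Across the three compounds, the change at this one nitrogen spans a 170-fold higher number from compound 1 to compound 3 (2.22 log units; beyond the scatter), with benzyl giving the lowest number and methylsulfonyl the highest. No evidence on the cause of this result is available. 

From the compounds shown here alone, whether a methyl group, a longer chain or a substituted benzyl would give a lower number than benzyl remains open, as does the result for the free ring amine.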